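Swapping 3-methylphenyl for 2-fluorophenyl in compound 3

The source may hold more compounds than are shown below. What is called first, only, known or untested is meant among the compounds shown, and "the series" means these compounds.

Measured in a functional assay on HT-29 cells (Homo sapiens) for inhibition, read by CCK-8 assay, with a stated time of 24 h; on this read-out lower numbers stand for stronger inhibition and higher numbers for weaker inhibition
Compound 1 `Cc1cccc(-n2cc(-c3ccc(/C=C4\C(=O)Nc5ccccc54)cc3)nn2)c1` gives 3940 nM
Compound 2 `O=C1Nc2ccccc2/C1=C/c1ccc(-c2cn(-c3cccc(Cl)c3)nn2)cc1` gives > 20000 nM, which is a limit of the assay and not a number
Compound 3 `Cc1cccc(-n2cc(-c3ccc(/C=C4\C(=O)Nc5ccc(F)cc54)cc3)nn2)c1` gives 7320 nM

Only compound 1 and compound 3 have true numbers here. Compound 3 stands closest to compound 1, and the step between them, a 1.9-fold higher number from compound 1 to compound 3 (0.27 log units; within the scatter), is too small to separate the two. Compound 2 sits at the limit of > 20000 nM in this assay, at which 1 of the 3 values shown sits.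

The next compound is compound 4 `O=C1Nc2ccc(F)cc2/C1=C/c1ccc(-c2cn(-c3ccccc3F)nn2)cc1`, which keeps the core of compound 3. Only the group on an aromatic nitrogen of the five-membered aromatic ring with 3 nitrogen changes, with 2-fluorophenyl in place of 3-methylphenyl (2-fluorophenyl in place of 3-methylphenyl on an aromatic nitrogen).

Among the compounds with values here, no measured step makes this exact swap. The nearest guide is an at least 5.0-fold higher number from compound 1 to compound 2 (0.70 log units; beyond the scatter), where the methyl on that same outer phenyl group was replaced and the number clearly rose. This single case points the same way for compound 4, although it is weak evidence. The other step, a 1.9-fold higher number from compound 1 to compound 3 (0.27 log units; within the scatter), changes the core at a point that compound 3 and compound 4 share, so it says little here.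

A modest rise is therefore expected, and the estimate is a 1.6-fold higher number from compound 3 to compound 4 (0.21 log units; within the scatter). Compound 4 is estimated at 12000 nM, with an expected range from 5000 nM to 28000 nM.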

Compound 4, half-maximal inhibitory concentration: 8980 nM
The estimate for compound 4 lay 1.3-fold (0.13 log units) above the measured number; low and high end bracket the measured number.
By their numbers in this assay, from the lowest: compounds 1, 3 and 4 (each within the scatter of the next, the first and the last beyond it). At a limit, above all of these: compound 2.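

In this assay, the group on the aromatic nitrogen of the five-membered aromatic ring with 3 nitrogen can go from 3-methylphenyl to 2-fluorophenyl with only a 1.2-fold higher number from compound 3 to compound 4 (0.09 log units; within the scatter), so compound 3 and compound 4 cannot be told apart. Within the data shown here, this is the first sign that the outer phenyl group can be changed without a step beyond the scatter, whereas the one earlier change there, chloro in place of methyl on the core of compound 1, gave an at least 5.0-fold higher number from compound 1 to compound 2 (0.70 log units; beyond the scatter). That earlier step ends at a limit of the assay, not at a true number: the limit of > 20000 nM in this assay, at which 1 of the 4 values shown sits.

Nothing measured here explains why one change on this phenyl group gives so small a step and the other a clear one. Still open, going by these compounds, is whether 2-fluorophenyl would give a similar number on the core of compound 1, which has hydrogen where compound 3 carries fluoro, and whether an outer phenyl group bearing an amine or a carboxylic acid would fit the same picture.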